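Moving the Methyl on the Benzyl Group of Compound 1

The source may report more compounds than this note shows. Statements on the series, on what has been measured and on what is new or still open speak of the compounds shown alone.

Going by the values given here, compound 1, `CCCn1c(=O)c2nc(-c3cnn(Cc4cccc(C)c4)c3)[nH]c2n(CCC)c1=O`, stands lowest of the three numbers measured so far in an in vitro assay on HEK293 cells for displacement of a labelled ligand from adenosine receptor A2b (Homo sapiens) (a higher number here means a weaker inhibitor, a lower number a stronger inhibitor), giving 36 nM. Compound 2, `CC(C)Cn1c(=O)c2nc(-c3cnn(Cc4cccc(C(F)(F)F)c4)c3)[nH]c2n(CC(C)C)c1=O`, gives 300 nM in this assay, and compound 3, `CCCn1c(=O)c2nc(-c3cnn(Cc4cc(C(F)(F)F)cc(Cl)c4F)c3)[nH]c2n(CCC)c1=O`, gives 360 nM; both of those gaps to compound 1 lie beyond the scatter. Compound 4, `CCCn1c(=O)c2nc(-c3cnn(Cc4ccccc4C)c3)[nH]c2n(CCC)c1=O`, has not yet been measured. It differs from compound 1 in one place: 2-methylphenyl in place of 3-methylphenyl on a saturated chain carbon bound to an aromatic nitrogen. Among the compounds with values here, no measured pair isolates such a change, so the size of the step can only be guessed. Compound 4 is expected to show a step of a 1.7-fold higher number from compound 1 to compound 4 (0.22 log units; within the scatter) that stays close to the scatter, if anything a mild drift toward a higher number. Compound 4 is therefore estimated at 60 nM, with a range from 20 nM to 200 nM.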

Compound 4, inhibition constant: 33 nM
The estimate for compound 4 lay 1.8-fold (0.26 log units) above the measured number; the measured number falls inside the stated range.
By their numbers in this assay, from the lowest: compounds 4 and 1 (each within the scatter of the next); then compounds 2 and 3 (each within the scatter of the next).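

In this assay, replacing 3-methylphenyl with 2-methylphenyl on a saturated chain carbon bound to an aromatic nitrogen gives a 1.1-fold lower number from compound 1 to compound 4 (0.04 log units; within the scatter). Going by these compounds alone, this is the first pair that differs in one place, and it shows that this change alone does not separate the two compounds beyond the scatter. Nothing available bears on this result. Still open, going by these compounds, is whether a methoxy group, an amine or a carboxylic acid in place of the methyl would keep the number near that of compound 1.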